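The source may report more compounds than this note shows. Statements on the series, on what has been measured and on what is new or still open speak of the compounds shown alone.

Compound 1 `CNCC(=O)Nc1cc(OC)ccc1C(=O)c1cc(OC)c(OC)c(OC)c1`, compound 2 `COc1ccc(C(=O)c2cc(OC)c(OC)c(OC)c2)c(NC(=O)CN(C)C)c1` and compound 3 `C=C(c1ccc(OC)cc1NC(=O)CN)c1ccc(OC)c2c1OC(C)(C)C=C2` have each been tested in a functional assay on HeLa cells (Homo sapiens) for antiproliferative activity, read by MTT assay, with a stated time of 48 h; a lower number here means a stronger inhibitor, a higher number a weaker inhibitor. In this assay compound 1 gives 690 nM, compound 2 gives 470 nM, and compound 3 gives 120 nM. The change from compound 1 to compound 2 is methyl in place of hydrogen on an amine nitrogen, and it made a 1.5-fold lower number from compound 1 to compound 2 (0.17 log units; within the scatter). Compound 3 has the lowest of the three numbers; the difference between its core and the core of compound 1 is not broken down here.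

Compound 4 `C=C(c1ccc(OC)cc1NC(=O)CNC)c1ccc(OC)c2c1OC(C)(C)C=C2` has not yet been measured. It differs from compound 3 by methyl in place of hydrogen on an amine nitrogen. This is the same kind of change as that from compound 1 to compound 2, but the place is not identical: in compound 3 the amine nitrogen has one saturated chain carbon as its other neighbour, whereas in compound 1 it has two saturated chain carbons. Because the earlier step of a 1.5-fold lower number from compound 1 to compound 2 (0.17 log units; within the scatter) stayed small, the expected step here is a 1.2-fold lower number from compound 3 to compound 4 (0.08 log units; within the scatter), also small. Compound 4 is therefore estimated at 100 nM, with a likely range from 50 nM to 200 nM.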

Compound 4, half-maximal inhibitory concentration: 310 nM
Compound 4: middle estimate off by 3.1-fold (0.49 log units), on the low side; measured number outside the range, above it.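

In this assay the added methyl gives a 2.6-fold higher number from compound 3 to compound 4 (0.41 log units; beyond the scatter), so on the core of compound 3 this small change costs some activity. Set beside the earlier step, the same change does not carry over unchanged from one core to the other: the same change on two cores in this assay, a 1.5-fold lower number (0.17 log units; within the scatter) from compound 1 to compound 2 and a 2.6-fold higher number (0.41 log units; beyond the scatter) from compound 3 to compound 4, 3.8-fold (0.58 log units) apart, beyond the scatter of two such steps. This does not show why the two steps differ, since the pairs differ both in the core and in the amine nitrogen itself, which has one saturated chain carbon as its other neighbour in compound 3 and two in compound 1, and two pairs cannot separate these influences or set a rule for the series.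

Still open, from the compounds shown here alone, is how a second methyl on this nitrogen would behave on the core of compound 3, and how a plain amino group would behave on the core of compound 1. Also open, going by these compounds, is whether an ethyl or a longer chain on this nitrogen would follow either step.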